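Fluoro to Chloro on the Aryl Ring of Compound 3

A few compounds are considered here, and "the series" means these few. Any claim that something is new, unique, unknown or untested is made for them only; others in the source may bear on it.

Compound 1 `O=C(O)c1csc(-n2nc(-c3ccccc3)c3c2CCCC3)n1`: 16 nM
Compound 2 `O=C(O)c1csc(-n2nc(-c3ccccc3)c3cccnc32)n1`: 200 nM
Compound 3 `O=C(O)c1csc(-n2nc(-c3ccc(F)cc3)c3ccccc32)n1`: 4.5 nM

Of the compounds shown here, three have been measured in an assay on isolated protein for antagonist activity at prostaglandin E2 receptor EP1 subtype (Homo sapiens), read by reporter gene assay; on this read-out lower numbers stand for stronger inhibition and higher numbers for weaker inhibition. Compound 1 gives 16 nM, compound 2 gives 200 nM, and compound 3 gives 4.5 nM. Among the compounds with values here, compound 3 stands lowest of the three; its gap to compound 1 is beyond the scatter, and its gap to compound 2 is wider still, so compound 3 is the most potent compound measured so far.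

Compound 4 `O=C(O)c1csc(-n2nc(-c3ccc(Cl)cc3)c3ccccc32)n1` has not yet been measured in this assay. It differs from compound 3 in one place: chloro in place of fluoro on an aromatic carbon. Within the data shown here, no step between two measured compounds shows what such an exchange does on this core, so the expectation rests on compound 3 alone. A swap of one halogen for another at the same position is a small change, and no large move in this assay is expected in either direction; if anything, a slight shift toward a lower number is anticipated. The estimated step from compound 3 to compound 4 is a 1.1-fold lower number from compound 3 to compound 4 (0.05 log units; within the scatter). Compound 4 is therefore expected to give about 4 nM in this assay, with a plausible range from 1.5 nM to 12 nM.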

Compound 4, half-maximal inhibitory concentration: 12 nM
Estimate against measurement, compound 4: 3.0-fold (0.48 log units) below; the measured number falls inside the stated range.
By their numbers in this assay, from the lowest: compound 3; then compounds 4 and 1 (each within the scatter of the next); then compound 2.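

In this assay, within the data shown here, the exchange of 4-fluorophenyl for 4-chlorophenyl supplies the only step on this core that can be read between two measured compounds, a 2.7-fold higher number from compound 3 to compound 4 (0.43 log units; beyond the scatter). It shows that the position para to a large group is not indifferent to which halogen it carries: a swap of one heavy atom for another, with no ring, net charge, or hydrogen-bond donor or acceptor entering or leaving, moves the number modestly but beyond the scatter, and the fluoro compound gives the lower number. The compounds shown offer no separate measurement that would account for this step.

Going by these compounds, whether the trend runs beyond these two halogens stays open, as bromo, methyl, methoxy or trifluoromethyl at this same place could fall on either side of the pair, and a single step cannot fix a direction for the position as a whole. On these data alone, it also remains open whether the same exchange would shift the number in the same direction and by a similar amount on the cores of compound 1 and compound 2.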